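The source may hold more compounds than are shown below. What is called first, only, known or untested is meant among the compounds shown, and "the series" means these compounds.

In a functional assay on Huh-7 cells (Homo sapiens) for cytotoxicity, with a stated time of 48 h (on this read-out higher numbers stand for weaker inhibition and lower numbers for stronger inhibition), compound 1 `O=[N+]([O-])c1ccc(CN2CCC(n3cc(CC(OCc4cc(-c5ccc(Br)cc5)no4)c4ccc(Br)cc4)nn3)CC2)cc1` gives 2000 nM, compound 2 `O=[N+]([O-])c1ccc(CN2CCC(n3cc(CC(OCc4cc(-c5cccc(F)c5)no4)c4ccc(Br)cc4)nn3)CC2)cc1` gives 3000 nM, and compound 3 `COc1cccc(-c2cc(COC(Cc3cn(C4CCN(Cc5ccc([N+](=O)[O-])cc5)CC4)nn3)c3ccc(Br)cc3)on2)c1` gives 5000 nM, the highest of the three numbers, though its gap to compound 2 is within the scatter. The step of a 1.7-fold higher number from compound 2 to compound 3 (0.22 log units; within the scatter) lies within the scatter, while the step of a 2.5-fold higher number from compound 1 to compound 3 (0.40 log units; beyond the scatter) is a modest one. Compound 4 `N#Cc1cccc(-c2cc(COC(Cc3cn(C4CCN(Cc5ccc([N+](=O)[O-])cc5)CC4)nn3)c3ccc(Br)cc3)on2)c1` carries cyano in place of methoxy on an aromatic carbon. Within the data shown here, no measured step involves a cyano group, and the three measured variants of that group all give numbers close together, so only a small shift is expected in this assay. The step from compound 3 to compound 4 is estimated as a 1.3-fold lower number from compound 3 to compound 4 (0.10 log units; within the scatter). Compound 4 is therefore expected to give about 4000 nM, with a likely range from 1500 nM to 12000 nM.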

Compound 4, half-maximal inhibitory concentration: 3000 nM
Compound 4: the middle estimate sits 1.3-fold (0.12 log units) above what was measured, within the range that was stated.
By their numbers in this assay, from the lowest: compounds 1, 2, 4 and 3 (each within the scatter of the next, the first and the last beyond it).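

Cyano on this aromatic carbon gives three steps in this assay that all stay within the scatter: a 1.7-fold lower number from compound 3 to compound 4 (0.22 log units; within the scatter) and no change at the digits printed from compound 2 to compound 4 (within the scatter) and a 1.5-fold higher number from compound 1 to compound 4 (0.18 log units; within the scatter) are all small. Compound 4 therefore cannot be told apart from any of the other three compounds, although compound 1 and compound 3 remain separated beyond the scatter. No measurement shown here explains these numbers. Going by these compounds, whether an amine or a carboxylic acid on this carbon would move the number beyond the scatter stays open, as does the effect of cyano elsewhere on this ring.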